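Benzimidazole-free note: removing the benzoyl ring methyl in the series

A few compounds are considered here, and "the series" means these few. Any claim that something is new, unique, unknown or untested is made for them only; others in the source may bear on it.

Measured compounds:
compound 1 `Cc1ccc(-c2nn(-c3ccccc3)cc2-c2nc3ccccc3n2C(=O)c2ccccc2C)cc1` — 176000 nM
compound 2 `Cc1ccccc1C(=O)n1c(-c2cn(-c3ccccc3)nc2-c2ccc(F)cc2)nc2ccccc21` — 189000 nM

In an ADME assay on HEK-293T cells (Homo sapiens) for cytotoxicity, read by MTT assay, with a stated time of 24 h (on this read-out lower numbers stand for higher toxicity in this test and higher numbers for lower toxicity in this test), compound 1 gives 176000 nM and compound 2 gives 189000 nM. Going by the values given here, compound 1 holds the lowest of the two numbers; its nearest neighbour is compound 2, and the one measured step, a 1.1-fold higher number from compound 1 to compound 2 (0.03 log units; within the scatter), is within the scatter, so the two compounds cannot be ordered on these data.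

Compound 3 `Cc1ccc(-c2nn(-c3ccccc3)cc2-c2nc3ccccc3n2C(=O)c2ccccc2)cc1` is not yet measured in this assay. It differs from compound 1 by hydrogen in place of methyl on an aromatic carbon: the (2-methylphenyl)carbonyl of compound 1 becomes a benzoyl.

Among the compounds with values here, no measured step touches this part of the shared core. Within the data shown here, the only step available, a 1.1-fold higher number from compound 1 to compound 2 (0.03 log units; within the scatter), concerns the aryl on the pyrazole and shows that a small change on an aromatic carbon at that position left this assay unchanged within the scatter. Among the measured compounds shown here, that is the sole guide here and it does not speak to the benzoyl directly.

With nothing pointing either way, no step beyond the scatter is expected for compound 3, so no change at the digits printed from compound 1 to compound 3 (within the scatter) is the estimated step. Compound 3 is therefore expected to give 176000 nM in this assay, within a range from 88000 nM to 350000 nM.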

Compound 3, half-maximal cytotoxic concentration: 204000 nM
Beside the measured number, compound 3's estimate is 1.2-fold (0.06 log units) below it; measured number inside the range.
By their numbers in this assay, from the lowest: compounds 1, 2 and 3 (each within the scatter of the next).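

In this assay, replacing the methyl on an aromatic carbon ortho to a large group with hydrogen, which turns the (2-methylphenyl)carbonyl into a benzoyl, gives a 1.2-fold higher number from compound 1 to compound 3 (0.06 log units; within the scatter). Going by these compounds alone, this is the first direct reading at this position, and it shows that this methyl can be exchanged for hydrogen without a change that can be told from the scatter, a result that a 1.1-fold higher number from compound 1 to compound 2 (0.03 log units; within the scatter) at the other changed place could not give. No supporting data bear on why the read-out stays within the scatter for this change.

The compounds shown compare only methyl and hydrogen at this carbon, so it remains open whether an amine, a carboxylic acid or a longer chain there would produce a step beyond the scatter. From the compounds shown here alone, it also remains open whether the same exchange of methyl for hydrogen would give a similar result with the fluoro group of compound 2 in place.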